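Swapping a Methyl for an Amino Group

This account rests on a few compounds, and the source may have more. Where it says the series, first, only, none or still open, it means among the compounds named here.

In a functional assay on the whole organism (stomach) with Canis familiaris (Canis lupus familiaris) as the target (on this read-out lower numbers stand for an effect already at smaller amounts and higher numbers for an effect only at larger amounts of compound), compound 1 (`Cc1nc2c(CCc3ccccc3)cccn2c1N`) gives 1 mg/kg and compound 2 (`Cc1nc2c(OCc3ccccc3)cccn2c1C`) gives 0.1 mg/kg as the lower of the two numbers, a gap beyond the usual scatter. Compound 3 (`Cc1nc2c(OCc3ccccc3)cccn2c1N`) differs from compound 2 at one place, with amino in place of methyl on an aromatic carbon. Going by the values given here, no measured pair shows this change alone, though compound 1 also carries amino and stands at 1 mg/kg in this assay. A moderate rise in the number is therefore expected, an estimated 3.0-fold higher number from compound 2 to compound 3 (0.48 log units; beyond the scatter) on this read-out. The expected value for compound 3 is 0.3 mg/kg (estimated range 0.08 mg/kg to 1.2 mg/kg).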

Compound 3, dose for half-maximal effect in the Canis familiaris assay: 0.1 mg/kg
Beside the measured number, compound 3's estimate is 3.0-fold (0.48 log units) above it; the range from low to high includes it.
By their numbers in the Canis familiaris assay, from the lowest: compounds 2 and 3 (each within the scatter of the next); then compound 1.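

In the Canis familiaris assay compound 2 gives 0.1 mg/kg and compound 3 gives 0.1 mg/kg. In the Canis familiaris assay putting amino in place of methyl on this aromatic carbon gives no change at the digits printed from compound 2 to compound 3 (within the scatter) so at this position the dose read-out does not separate the two groups, even though amino adds a hydrogen-bond donor. In a physicochemical assay for acid dissociation, compound 2 gives 7 and compound 3 gives 6.81. In the physicochemical assay the same change gives a number 0.19 log units lower from compound 2 to compound 3 (within the scatter) so that read-out does not separate them either. Nothing measured here explains why the two groups match. Still open, from the compounds shown here alone, is how a larger group at this position, such as dimethylamino or a carboxylic acid, would fare in the Canis familiaris assay.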